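Fluoro on the phenyl: expected clearance in the urea series

The source may report more compounds than this note shows. Statements on the series, on what has been measured and on what is new or still open speak of the compounds shown alone.

Compound 1 `Cc1cccnc1N(C(=O)N1CCC(c2ccccc2)CC1)[C@@H]1CCCNC1`: < 8 mL.min-1.g-1
Compound 2 `O=C(N1CCC(c2ccccc2)CC1)N(c1nccc2ccccc12)[C@@H]1CCCNC1`: 13.9 mL.min-1.g-1
Compound 3 `Cn1ccc2ccnc(N(C(=O)N3CCC(c4ccccc4)CC3)[C@@H]3CCCNC3)c21`: 11.8 mL.min-1.g-1

All three have been run in an ADME assay on microsomes from liver (Homo sapiens) for metabolic stability; on this read-out lower numbers stand for slow clearance and higher numbers for fast clearance. Compound 1 returns < 8 mL.min-1.g-1 in this assay, which is a limit of the assay and not a number (the limit of < 8 mL.min-1.g-1 in this assay, at which 1 of the 3 values shown sits). Compound 2 gives 13.9 mL.min-1.g-1 in this assay. Compound 3 gives 11.8 mL.min-1.g-1 in this assay, and the pair sits within the scatter of each other (a 1.2-fold lower number from compound 2 to compound 3 (0.07 log units; within the scatter)). From compound 1 the steps read an at least 1.7-fold higher number from compound 1 to compound 2 (0.23 log units; that floor lies within the scatter) and an at least 1.4-fold higher number from compound 1 to compound 3 (0.16 log units; that floor lies within the scatter), each only a floor that lies within the scatter. Every measured step changes the group on the amide-type nitrogen; none touches the phenyl.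

Compound 4 `Cc1cccnc1N(C(=O)N1CCC(c2ccccc2F)CC1)[C@@H]1CCCNC1` differs from compound 1 by fluoro in place of hydrogen on an aromatic carbon. Within the data shown here, no measured step bears on this change, so no step beyond the scatter is expected in this assay from compound 1 to compound 4, and the change is read as neutral. Compound 4 is expected to give about 8 mL.min-1.g-1 in this assay, within a range of 4 mL.min-1.g-1 to 16 mL.min-1.g-1. This means an expected step of a number no lower from compound 1 to compound 4 (the limit leaves the size open). Since compound 1 stands at a limit, compound 4 may again return only a limit rather than a number.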

Compound 4, intrinsic clearance in microsomes: < 8 mL.min-1.g-1
Compound 4: only a limit was reported (the forecaster's own chance of this, stated with the estimate: 55%); the middle value sits exactly at the limit.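

In this assay compound 4 returns < 8 mL.min-1.g-1, which is a limit of the assay and not a number. Compound 1 stands at a limit as well, and no step can be read between compound 1 and compound 4. The compounds shown leave open whether phenyl to 2-fluorophenyl shifts clearance at all in this series.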